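This account rests on a few compounds, and the source may have more. Where it says the series, first, only, none or still open, it means among the compounds named here.

Measured in a functional assay on SW480 cells (Homo sapiens) for antiproliferative activity, read by MTT assay, with a stated time of 72 h; a lower number here means a stronger inhibitor, a higher number a weaker inhibitor:

- compound 1 `COc1ccc2oc(CSC(=S)N3CCOCC3)cc(=O)c2c1`: 3100 nM
- compound 2 `COc1ccc2oc(CSC(=S)N(C(C)C)C(C)C)cc(=O)c2c1`: 7200 nM
- compound 3 `O=c1c(CSC(=S)N2CCOCC2)coc2ccccc12`: 5900 nM

Compound 1 and compound 2 share a core and differ at one place, (diisopropylamino in place of morpholin-4-yl on a thiocarbonyl carbon). This change gave a 2.3-fold higher number from compound 1 to compound 2 (0.37 log units; beyond the scatter), a shift beyond the usual scatter, so in this pair the diisopropylamino member is the weaker inhibitor.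

Compound 3 carries a different core from compound 1; the difference between the two cores is not broken down here. Its value sits near that of compound 2 and that of compound 1, both within the scatter, so no ordering among these three is claimed beyond the one step above.

Compound 4 `CC(C)N(C(=S)SCc1coc2ccccc2c1=O)C(C)C` has not been measured. It stands to compound 3 exactly as compound 2 stands to compound 1: diisopropylamino in place of morpholin-4-yl on a thiocarbonyl carbon. The place line is the same word for word, so this is the same change, now on the core of compound 3.

The expectation is that the step repeats, a 2.2-fold higher number from compound 3 to compound 4 (0.34 log units; beyond the scatter), resting on compound 1 and compound 2 because a 2.3-fold higher number from compound 1 to compound 2 (0.37 log units; beyond the scatter) was observed on the other core. Compound 4 is therefore expected to give about 13000 nM in this assay, with a likely range from 5000 nM to 35000 nM.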

Compound 4, half-maximal inhibitory concentration: 6800 nM
Estimate against measurement, compound 4: 1.9-fold (0.28 log units) above; low and high end bracket the measured number.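

In this assay, diisopropylamino in place of morpholin-4-yl on the core of compound 3 gave a 1.2-fold higher number from compound 3 to compound 4 (0.06 log units; within the scatter), so the two members of this pair cannot be ordered. Set beside the earlier step, this result does not separate the two cores: the same change on two cores in this assay, a 2.3-fold higher number (0.37 log units; beyond the scatter) from compound 1 to compound 2 and a 1.2-fold higher number (0.06 log units; within the scatter) from compound 3 to compound 4, 2.0-fold (0.30 log units) apart, within the scatter of two such steps. Among these compounds, the change can therefore be carried from one core to the other without a detectable difference in the step, but this does not show a repeated loss of activity: only the step on the core of compound 1 lies beyond the scatter, and a single pair on each core does not fix the size of the step on either.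

On these data alone, whether other amines on the thiocarbonyl carbon, such as piperidin-1-yl, piperazin-1-yl or diethylamino, would behave alike on both cores remains open. Also open, as far as these compounds go, is which part of the difference between the two cores, if any, bears on the size of the step.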